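The compounds below may be only part of what the source reports. "The series", "measured", "known", "first", "only" and "open" are said of these compounds alone.

Of the compounds shown here, three built on one shared core have been measured in an ADME assay on microsomes from liver (Homo sapiens) for metabolic stability, with a stated time of 10 min; a higher number here means that more of the compound is left, a lower number that less of the compound is left. Compound 1 `O=C(NS(=O)(=O)c1ccccc1)c1ccc(Nc2nc(NC3(c4ccc(Cl)cc4)CC3)nc(OCC(F)(F)F)n2)cc1` gives 100%. Compound 2 `CC(C)(C)NC(=O)NCCS(=O)(=O)NC(=O)c1ccc(Nc2nc(NC3(c4ccc(Cl)cc4)CC3)nc(OCC(F)(F)F)n2)cc1` gives 96%, and compound 3 `CNC(=O)NCCS(=O)(=O)NC(=O)c1ccc(Nc2nc(NC3(c4ccc(Cl)cc4)CC3)nc(OCC(F)(F)F)n2)cc1` gives 97%. Among these three numbers compound 3 stands second highest; its nearest neighbour is compound 2 and its furthest is compound 1, and both a number 3 percentage points lower from compound 1 to compound 3 (within the scatter) and a number 1 percentage points higher from compound 2 to compound 3 (within the scatter) lie within the scatter, as does a number 4 percentage points lower from compound 1 to compound 2 (within the scatter).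

Compound 4 `CS(=O)(=O)NC(=O)c1ccc(Nc2nc(NC3(c4ccc(Cl)cc4)CC3)nc(OCC(F)(F)F)n2)cc1` differs from compound 3 by hydrogen in place of ((methylcarbamoyl)amino)methyl on a saturated chain carbon bound to a sulfonyl sulfur. For the measured compounds named here, the steps that bear on this change are those that alter the group on a sulfonyl sulfur or on an amide-type nitrogen within it: a number 4 percentage points lower from compound 1 to compound 2 (within the scatter), a number 3 percentage points lower from compound 1 to compound 3 (within the scatter) and a number 1 percentage points higher from compound 2 to compound 3 (within the scatter), each within the scatter. Because a number 1 percentage points higher from compound 2 to compound 3 (within the scatter) and a number 3 percentage points lower from compound 1 to compound 3 (within the scatter) both lie within the scatter, no step beyond the scatter is expected here either, and the expected change is no change at the digits printed from compound 3 to compound 4 (within the scatter). Compound 4 is therefore estimated to give 97% in this assay, with a range from 88% to 100%.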

Compound 4, percent of the compound remaining: 100%
The estimate for compound 4 lay 3 percentage points below the measured number; the range from low to high includes it.
By their numbers in this assay, from the lowest: compounds 2, 3, 1 and 4 (each within the scatter of the next).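

In this assay, taking the whole ((methylcarbamoyl)amino)methyl group off the saturated chain carbon bound to a sulfonyl sulfur gives a number 3 percentage points higher from compound 3 to compound 4 (within the scatter), and the matching removal of the tert-butyl urea-bearing group gives a number 4 percentage points higher from compound 2 to compound 4 (within the scatter). Methyl in place of phenyl on the sulfonyl sulfur gives no change at the digits printed from compound 1 to compound 4 (within the scatter), so a group on this sulfur as small as methyl now joins phenyl and the two urea-bearing chains, with no step among them beyond the scatter. No measurement shown here explains this insensitivity.

On these data alone, it remains open whether an amine, a carboxylic acid or a longer chain at this position would bring a step beyond the scatter. With all four compounds within the scatter, these numbers cannot show which parts of the shared core, if any, govern the read-out.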